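Swapping the Amine Side Group on a Shared Core

The source may report more compounds than this note shows. Statements on the series, on what has been measured and on what is new or still open speak of the compounds shown alone.

Compound 1 `COc1ccc(Nc2cc(C)nc(SCc3nc4ccccc4[nH]3)n2)cc1`: 51100 nM
Compound 2 `Cc1ccc(Nc2cc(C)nc(SCc3nc4ccccc4[nH]3)n2)cc1`: 7390 nM
Compound 3 `Cc1cc(N2CCNCC2)nc(SCc2nc3ccccc3[nH]2)n1`: > 100000 nM

Three compounds were tested in a functional assay on MGC-803 cells (Homo sapiens) for cytotoxicity, read by MTT assay, with a stated time of 72 h; on this read-out lower numbers stand for stronger inhibition and higher numbers for weaker inhibition. Compound 1 gives 51100 nM and compound 2 gives 7390 nM, the step between them being a 6.9-fold lower number from compound 1 to compound 2 (0.84 log units; beyond the scatter). For compound 3 only a limit of the assay is known, > 100000 nM, (the limit of > 100000 nM in this assay, at which 1 of the 3 values shown sits).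

Compound 4 `COc1ccccc1Nc1cc(C)nc(SCc2nc3ccccc3[nH]2)n1` differs from compound 3 by (2-methoxyphenyl)amino in place of piperazin-1-yl on an aromatic carbon. Within the data shown here, two measured steps bear on this change, each running the other way and each putting an arylamino group in place of piperazin-1-yl: an at least 1.9-fold higher number from compound 1 to compound 3 (0.29 log units; that floor lies within the scatter) and an at least 13-fold higher number from compound 2 to compound 3 (1.13 log units; beyond the scatter). A step toward a lower number is therefore expected, and the expected step is an at least 2.5-fold lower number from compound 3 to compound 4 (0.39 log units; beyond the scatter). Compound 4 is expected to give 40000 nM, within a range of 10000 nM to 100000 nM.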

Compound 4, half-maximal inhibitory concentration: 56200 nM
Estimate against measurement, compound 4: 1.4-fold (0.15 log units) below; the range from low to high includes it.
By their numbers in this assay, from the lowest: compound 2; then compounds 1 and 4 (each within the scatter of the next). At a limit, above all of these: compound 3.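

In this assay, the methoxy group can sit on either carbon shown with no readable change: 2-methoxyphenyl in place of 4-methoxyphenyl gives a 1.1-fold higher number from compound 1 to compound 4 (0.04 log units; within the scatter). Against the 4-methylphenyl group of compound 2, the 2-methoxyphenyl group gives a 7.6-fold higher number from compound 2 to compound 4 (0.88 log units; beyond the scatter), so the gain remains confined to compound 2. The comparison with piperazin-1-yl, an at least 1.7-fold lower number from compound 3 to compound 4 (0.25 log units; that floor lies within the scatter), cannot be read because compound 3 stands at a limit: the limit of > 100000 nM in this assay, at which 1 of the 4 values shown sits.

From the compounds shown here alone, it remains open whether 2-methylphenyl or 4-chlorophenyl on the same nitrogen would match compound 2. Going by these compounds, it also remains open how an open-chain amine would compare with piperazin-1-yl.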